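The source may report more compounds than this note shows. Statements on the series, on what has been measured and on what is new or still open speak of the compounds shown alone.

In a functional assay on HepG2 cells (Homo sapiens) for inhibition, read by MTT assay, with a stated time of 72 h (on this read-out lower numbers stand for stronger inhibition and higher numbers for weaker inhibition), compound 1 `COc1ccc(/C=C/C(=O)c2c(OC)cc(O)c(CC=C(C)C)c2O)cc1` gives 32400 nM and compound 2 `COc1cc(O)c(CC=C(C)C)c(O)c1C(=O)/C=C/c1ccc(O)c(O)c1` gives 15200 nM. Compound 3 `COc1cc(OC)c(OC)cc1/C=C/C(=O)c1c(OC)cc(O)c(CC=C(C)C)c1O` stands at a limit, > 50000 nM, and has no exact number. Compound 4 `COc1cc(OC)c(OC)cc1/C=C/C(=O)c1c(O)cc(O)cc1OC` differs from it by a single change: hydrogen in place of 3-methylbut-2-en-1-yl on an aromatic carbon. Hydrogen replaces the 3-methylbut-2-en-1-yl group on an aromatic carbon. For the measured compounds named here, no measured step covers this change. The only one, a 2.1-fold lower number from compound 1 to compound 2 (0.33 log units; beyond the scatter), is a modest step that swaps 4-methoxyphenyl for 3,4-dihydroxyphenyl, so it bears on this change only weakly. Compound 3 offers just the limit > 50000 nM as a starting point, so a small move toward weaker inhibition, perhaps none beyond the scatter, is expected. The expected step is a step that the limit leaves unreadable from compound 3 to compound 4. Compound 4 is estimated at 60000 nM, with an expected range of 25000 nM to 150000 nM.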

Compound 4, half-maximal inhibitory concentration: 18700 nM
Compound 4: the middle estimate sits 3.2-fold (0.51 log units) above what was measured, outside the stated range (below it).
By their numbers in this assay, from the lowest: compounds 2, 4 and 1 (each within the scatter of the next, the first and the last beyond it). At a limit, above all of these: compound 3.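

Hydrogen in place of 3-methylbut-2-en-1-yl on this aromatic carbon gives an at least 2.6-fold lower number from compound 3 to compound 4 (0.42 log units; beyond the scatter) in this assay, so in this pair inhibition does not depend on keeping the chain. The full size of the step cannot be read because compound 3 stands at a limit of the assay, not at an exact number: the limit of > 50000 nM in this assay, at which 1 of the 4 values shown sits.

On these data alone, whether the same swap acts alike in compound 1 and compound 2 stays open. So does how a methyl group, an amine or a carboxylic acid would fare on this carbon.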